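Swapping a Cyclopropyl Ester for a Nitrooxymethylphenyl Ester

The source may hold more compounds than are shown below. What is called first, only, known or untested is meant among the compounds shown, and "the series" means these compounds.

Within the data shown here, compound 1 `CC(=O)Oc1ccccc1C(=O)O[C@H]1CO[C@H]2[C@@H]1OC[C@H]2OC(=O)C1CC1` is one of two compounds measured in an ADME assay on a cell-free system (plasma, Homo sapiens) for metabolic stability, with Plasma (Rattus norvegicus) as the target, read by HPLC, at pH 7.4 (a higher number here means that the compound lasts longer, a lower number that the compound disappears faster), where compound 1 gives 0.0322 h, the lower of the two numbers. Among the measured compounds shown here, compound 2 `COc1ccc(C(=O)O[C@@H]2CO[C@H]3[C@@H]2OC[C@@H]3OC(=O)c2ccccc2OC(C)=O)cc1` gives 0.0525 h; the only measured step, a 1.6-fold higher number from compound 1 to compound 2 (0.21 log units; within the scatter), puts a 4-methoxyphenyl in place of the cyclopropyl on a carbonyl carbon. Compound 3 `CC(=O)Oc1ccccc1C(=O)O[C@H]1CO[C@H]2[C@@H]1OC[C@H]2OC(=O)c1ccc(CO[N+](=O)[O-])cc1` differs from compound 1 in a similar way: 4-((nitrooxy)methyl)phenyl in place of cyclopropyl on a carbonyl carbon. Because a 1.6-fold higher number from compound 1 to compound 2 (0.21 log units; within the scatter) stayed within the scatter, the expected step of a 1.4-fold higher number from compound 1 to compound 3 (0.15 log units; within the scatter) should also stay within the scatter. Compound 3 is therefore estimated at 0.045 h, with a range from 0.02 h to 0.1 h.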

Compound 3, half-life: 0.1 h
Compound 3: the middle estimate sits 2.2-fold (0.35 log units) below what was measured; low and high end bracket the measured number.
By their numbers in this assay, from the lowest: compounds 1, 2 and 3 (each within the scatter of the next, the first and the last beyond it).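

Among these compounds, at this carbonyl carbon, 4-((nitrooxy)methyl)phenyl in place of cyclopropyl gives the only step so far that lies beyond the scatter in this assay (this assay), a modest one (a 3.1-fold higher number from compound 1 to compound 3 (0.49 log units; beyond the scatter)). With (nitrooxy)methyl in place of methoxy on an aromatic carbon, the step stays within the scatter (a 1.9-fold higher number from compound 2 to compound 3 (0.28 log units; within the scatter)), so compound 2 and compound 3 cannot be told apart. No evidence is available to explain either step.

Still open, as far as these compounds go, is whether a plain phenyl at this carbonyl carbon would give a similar number to compound 3. Also open, from the compounds shown here alone, is how an amine, a carboxylic acid or a longer chain would behave there.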